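A few compounds are considered here, and "the series" means these few. Any claim that something is new, unique, unknown or untested is made for them only; others in the source may bear on it.

Measured in a functional assay on MDA-MB-231 cells (Homo sapiens) for antiproliferative activity, read by MTT assay, with a stated time of 24 h; on this read-out lower numbers stand for stronger inhibition and higher numbers for weaker inhibition:
- compound 1 `O=C(NNc1ccccc1F)c1cccc(NS(=O)(=O)c2cnc(O)nc2O)c1`: > 20000 nM
- compound 2 `O=C(NNc1ccccc1F)c1ccccc1NS(=O)(=O)c1cnc(O)nc1O`: > 20000 nM

Compound 1 gives only a limit and no number: the limit of > 20000 nM in this assay, at which 2 of the 2 values shown sit. Compound 2 likewise gives only a limit. Compound 3 `O=C(NNC(=O)c1cccc(NS(=O)(=O)c2cnc(O)nc2O)c1)c1cccc(Cl)c1` carries (3-chlorophenyl)carbonyl in place of 2-fluorophenyl on an amine nitrogen. Among the measured compounds shown here, no measured step shows the effect of this change. The only anchor for the expectation is compound 1 at its limit of > 20000 nM. The estimated step in this assay, a number no higher from compound 1 to compound 3 (the limit leaves the size open), is expected to stay within the scatter, with no direction favoured. For compound 3 the estimated value is 20000 nM, with an expected range of 6000 nM to 50000 nM.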

Compound 3, half-maximal inhibitory concentration: 3180 nM
For compound 3 the middle estimate is 6.3-fold (0.80 log units) above the measured one; the measured number lies below the stated range.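

In this assay, (3-chlorophenyl)carbonyl in place of 2-fluorophenyl on an amine nitrogen gives an at least 6.2-fold lower number from compound 1 to compound 3 (0.79 log units; beyond the scatter). This is the only change shown that yields a measured number rather than a limit, so this position responds to substitution. The full size of the step stays open, as compound 1 gives only a limit: the limit of > 20000 nM in this assay, at which 2 of the 3 values shown sit.

The change brings in the carbonyl and the chlorine together, and the compounds shown do not separate their contributions. From the compounds shown here alone, whether phenylcarbonyl without chlorine, or acetyl, on the same nitrogen gives a similar number remains open.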